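A few compounds are considered here, and "the series" means these few. Any claim that something is new, unique, unknown or untested is made for them only; others in the source may bear on it.

Three compounds built on the shared core of compound 1, `CCN1CCN(CCC(=O)Nc2nc3c(C)cccc3s2)CC1`, have been tested in an assay on membranes from liver for displacement of a labelled ligand from Sigma intracellular receptor 2 (Rattus norvegicus), read by scintillation counting, with a stated time of 120 min; on this read-out lower numbers stand for stronger inhibition and higher numbers for weaker inhibition. Compound 1 gives 1200 nM. Compound 2, `Cc1cccc2sc(NC(=O)CCN3CCN(CCN(C)C)CC3)nc12`, carries dimethylamino in place of hydrogen on a saturated chain carbon, two bonds along the chain from an amine nitrogen in a ring. In this assay compound 2 is reported only as a limit, > 1000 nM. Compound 3, `Cc1cccc2sc(NC(=O)CCN3CCN(CCCN(C)C)CC3)nc12`, carries (dimethylamino)methyl at that same place. In this assay compound 3 is likewise reported only as a limit, > 1000 nM. Compound 3 thus stands at the limit of > 1000 nM in this assay, at which 2 of the 3 values shown sit. The steps a step that the limit leaves unreadable from compound 1 to compound 2, a step that the limit leaves unreadable from compound 1 to compound 3 and a step that the two limits leave unreadable from compound 2 to compound 3 are left unreadable in size by those limits.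

Compound 4, `CCCCCCN1CCN(CCC(=O)Nc2nc3c(C)cccc3s2)CC1`, differs from compound 3 by propyl in place of dimethylamino on a saturated chain carbon, three bonds along the chain from an amine nitrogen in a ring; cut one bond further out, the same difference reads 3-(dimethylamino)propyl to hexyl. For the measured compounds named here, no measured step can be read, so none gives a size to carry over, and the only number available is that of compound 1, with ethyl on the ring amine nitrogen, at 1200 nM. The step that the limit leaves unreadable from compound 3 to compound 4 is therefore expected to be small, within the scatter. Compound 4 is expected to give about 1100 nM, with a range from 300 nM to 4000 nM.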

Compound 4, inhibition constant: 158 nM
Compound 4: middle estimate off by 7.0-fold (0.84 log units), on the high side; measured number outside the range, below it.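

In this assay, for the compounds shown here, the first readable step at this position shows that the group on the ring amine nitrogen can change the number: hexyl in place of ethyl gives a 7.6-fold lower number from compound 1 to compound 4 (0.88 log units; beyond the scatter), whereas the earlier steps could not be read. Hexyl also compares well with both chains ending in dimethylamino, with an at least 6.3-fold lower number from compound 3 to compound 4 (0.80 log units; beyond the scatter) and an at least 6.3-fold lower number from compound 2 to compound 4 (0.80 log units; beyond the scatter), so a plain carbon chain at this place does better than those two chains. These last two steps give only a minimum size, since compound 2 and compound 3 are reported as limits and not as numbers: the limit of > 1000 nM in this assay, at which 2 of the 4 values shown sit.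

From the compounds shown here alone, with only ethyl and hexyl as plain carbon chains on this nitrogen, it remains open whether the number falls steadily with chain length, and whether a longer chain such as octyl would take it lower still or lose ground. Going by these compounds, it also remains open how a hexyl chain ending in a hydroxyl group or a phenyl ring would compare, and so whether any group at the chain end can be tolerated or only dimethylamino counts against it.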